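The compounds below may be only part of what the source reports. "The series", "measured", "known", "first", "only" and "open" are said of these compounds alone.

Compound 1 `CCCCc1nnc(O)n2c(CCC)nc(C)c12` was tested in a functional assay for inhibition, with Homo sapiens as the target (a higher number here means a weaker inhibitor, a lower number a stronger inhibitor), and gave only a limit, > 48000 nM. Compound 2 `Cc1ncn2c(O)nncc12` was also tested in this assay and likewise gave only a limit, > 48000 nM. Neither compound has a number of its own, so compound 1 cannot be placed above or below compound 2; both simply sit at the limit, as the record shows: the limit of > 48000 nM in this assay, at which 2 of the 2 values shown sit. Compound 3 `CCCc1nc(C)c2c(-c3ccccc3)nnc(O)n12` has not yet been measured in this assay. It differs from compound 1 in one place (phenyl in place of butyl on an aromatic carbon), phenyl in place of butyl on an aromatic carbon. For the measured compounds named here, no step between measured compounds is available, and both values known so far are limits, so there is nothing to show that the change from compound 1 to compound 3 would move the read-out beyond the scatter; the expectation is no step beyond the scatter in this assay. The estimated step that the limit leaves unreadable from compound 1 to compound 3 is expected to be small. Compound 3 is therefore expected to give 60000 nM in this assay, with a range from 15000 nM to 200000 nM, and most likely again only a limit.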

Compound 3, half-maximal inhibitory concentration: > 48000 nM
Compound 3: no number, only a limit (the forecaster's own chance of this, stated with the estimate: 80%); the middle value is on the limit's open side.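

Compound 3, like compound 1, gave only a limit in this assay, so no step can be read for phenyl in place of butyl on an aromatic carbon: the limit of > 48000 nM in this assay, at which 3 of the 3 values shown sit. The compounds shown leave open how far each lies past that limit and whether any change to the shared core would give a readable value.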